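A few compounds are considered here, and "the series" means these few. Any claim that something is new, unique, unknown or untested is made for them only; others in the source may bear on it.

In a functional assay on OVCAR-3 cells (Homo sapiens) for antiproliferative activity, read by MTT assay, with a stated time of 24 h (a higher number here means a weaker inhibitor, a lower number a stronger inhibitor), compound 1 `Cc1cccc(NNC(=O)c2ccccc2NS(=O)(=O)c2cnc(O)nc2O)c1` gives > 20000 nM, which is a limit of the assay and not a number. Compound 2 `O=C(NNc1cccc(Cl)c1)c1ccccc1NS(=O)(=O)c1cnc(O)nc1O` gives 5520 nM. Compound 3 `O=C(NNc1ccccc1F)c1ccccc1NS(=O)(=O)c1cnc(O)nc1O` gives 9570 nM, and the gap to compound 2 is small: a 1.7-fold higher number from compound 2 to compound 3 (0.24 log units; within the scatter). The two therefore stand together, and both sit clear of the limit, with an at least 3.6-fold lower number from compound 1 to compound 2 (0.55 log units; beyond the scatter) and an at least 2.0-fold lower number from compound 1 to compound 3 (0.32 log units; beyond the scatter).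

Compound 4 `O=C(NNc1ccc(F)cc1)c1ccccc1NS(=O)(=O)c1cnc(O)nc1O` is an isomer of compound 3, with 4-fluorophenyl in place of 2-fluorophenyl on an amine nitrogen. Among the measured compounds shown here, no measured step makes this exact change. The closest is the exchange of 3-chlorophenyl for 2-fluorophenyl, a 1.7-fold higher number from compound 2 to compound 3 (0.24 log units; within the scatter), which stayed within the scatter. The two steps from compound 1 start from a limit, so they fix only a minimum size and say little here.

The step expected in this assay is a 1.2-fold lower number from compound 3 to compound 4 (0.08 log units; within the scatter), with no clear direction and nothing beyond the scatter anticipated. For compound 4 the estimated value is 8000 nM, with an expected range of 3500 nM to 18000 nM.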

Compound 4, half-maximal inhibitory concentration: > 20000 nM
Compound 4: a limit, no number; the forecaster's own chance of this, stated with the estimate: 15%; middle value at least 2.5-fold (0.39 log units) from the limit.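

In this assay, the same atoms joined differently are enough to separate two compounds: 4-fluorophenyl in place of 2-fluorophenyl on the amine nitrogen gives an at least 2.0-fold higher number from compound 3 to compound 4 (0.32 log units; beyond the scatter), whereas the exchange of 3-chlorophenyl for 2-fluorophenyl stayed within the scatter. The exchange of 3-chlorophenyl for 4-fluorophenyl gives an at least 3.6-fold higher number from compound 2 to compound 4 (0.55 log units; beyond the scatter), so among the compounds shown, the aryl groups on this nitrogen are not interchangeable. The value of compound 4 is a limit and not a number, so the step from compound 1 to compound 4 cannot be read: the limit of > 20000 nM in this assay, at which 2 of the 4 values shown sit.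

Going by these compounds, how far compound 4 lies past its limit remains open. So does whether 4-chlorophenyl, 4-methylphenyl or unsubstituted phenyl on this nitrogen would sit with compound 4 or with compound 2.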